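Bromo to dimethylamino on the styryl ring of two cores

A few compounds are considered here, and "the series" means these few. Any claim that something is new, unique, unknown or untested is made for them only; others in the source may bear on it.

Compound 1, `Cc1ccc(S/C(=C/c2ccc(Br)cc2)C(=O)c2ccc(Cl)cc2)cc1`, in a functional assay on DU-145 cells (Homo sapiens) for inhibition, read by trypan blue exclusion, with a stated time of 96 h (a lower number here means a stronger inhibitor of growth, a higher number a weaker inhibitor of growth), gives 25000 nM. Compound 2, `Cc1ccc(S/C(=C/c2ccc(N(C)C)cc2)C(=O)c2ccc(Cl)cc2)cc1`, in this assay gives only a limit, > 100000 nM. Compound 3, `O=C(/C(=C\c1ccc(Br)cc1)Sc1ccccc1Br)c1ccc(Br)cc1`, in this assay gives 1000 nM.

The change dimethylamino in place of bromo on an aromatic carbon is measured once: it reads as an at least 4.0-fold higher number from compound 1 to compound 2 (0.60 log units; beyond the scatter), and the end of that step is the limit (the limit of > 100000 nM in this assay, at which 1 of the 3 values shown sits), so the true size may be larger. Compound 3 has a different core; the difference between the two cores is not broken down here. Among the measured numbers compound 3 has the lowest, its nearest neighbour being compound 1.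

Compound 4, `CN(C)c1ccc(/C=C(/Sc2ccccc2Br)C(=O)c2ccc(Br)cc2)cc1`, is not yet measured in this assay. It stands to compound 3 as compound 2 stands to compound 1: the change (dimethylamino in place of bromo on an aromatic carbon), the same change at the same kind of place. Going by the values given here, the expectation for compound 4 rests on the one measured instance, where the step of an at least 4.0-fold higher number from compound 1 to compound 2 (0.60 log units; beyond the scatter) ran toward weaker growth inhibition. The step is therefore expected as a 20-fold higher number from compound 3 to compound 4 (1.30 log units; beyond the scatter). The estimate for compound 4 in this assay is 20000 nM, with a range from 4000 nM to 100000 nM.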

Compound 4, concentration for 50% growth inhibition: > 100000 nM
Compound 4 was reported as a limit; the forecaster's own chance of this, stated with the estimate: 25%; middle value at least 5.0-fold (0.69 log units) from the limit.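

On both cores, dimethylamino in place of bromo on an aromatic carbon runs toward weaker growth inhibition in this assay, here as an at least 100-fold higher number from compound 3 to compound 4 (2.00 log units; beyond the scatter). Compound 4 gives > 100000 nM, which is a limit of the assay and not a number. The direction of the change therefore carries across these two cores, but its size on one core cannot be compared with its size on the other: the same change on two cores in this assay, an at least 4.0-fold higher number (0.60 log units; beyond the scatter) from compound 1 to compound 2 and an at least 100-fold higher number (2.00 log units; beyond the scatter) from compound 3 to compound 4; the limit leaves it open whether they differ

The compounds shown leave open how large the step truly is on either core, and so whether the core alters it at all. Also open, from the compounds shown here alone, is how another group in the same place, such as a primary amine, a methoxy group or a carboxylic acid, would read against bromo on each core.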